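Methyl replaces nitro on the aryl ring of compound 3

A few compounds are considered here, and "the series" means these few. Any claim that something is new, unique, unknown or untested is made for them only; others in the source may bear on it.

Among the compounds with values here, compound 3 `O=[N+]([O-])c1ccc(Nc2ccc(N3CC4CC(C3)N4)nn2)cc1` gives 86.2 nM in an assay on cell membranes for displacement of a labelled ligand from Neuronal acetylcholine receptor; alpha4/beta2 (Rattus norvegicus) (a lower number here means a stronger inhibitor, a higher number a weaker inhibitor), the lowest of the three numbers measured so far. Compound 1 `Fc1ccc(Nc2ccc(N3CC4CC(C3)N4)nn2)cc1` gives 868 nM and compound 2 `COc1ccc(Nc2ccc(N3CC4CC(C3)N4)nn2)cc1` gives 578 nM; the step of a 1.5-fold lower number from compound 1 to compound 2 (0.18 log units; within the scatter) lies within the scatter, whereas a 10-fold lower number from compound 1 to compound 3 (1.00 log units; beyond the scatter) and a 6.7-fold lower number from compound 2 to compound 3 (0.83 log units; beyond the scatter) both lie beyond it. Compound 4 `Cc1ccc(Nc2ccc(N3CC4CC(C3)N4)nn2)cc1` differs from compound 3 only in the change (methyl in place of nitro on an aromatic carbon). Within the data shown here, no measured step exchanges nitro for methyl directly; the two steps that bear on it, a 10-fold lower number from compound 1 to compound 3 (1.00 log units; beyond the scatter) and a 6.7-fold lower number from compound 2 to compound 3 (0.83 log units; beyond the scatter), show that within this small set the nitro-bearing compound 3 stands apart, while compound 1 and compound 2, which carry fluoro and methoxy, sit close to each other. Taking the nitro group away is therefore expected to undo most of that separation, so a modest step upward, a 7.0-fold higher number from compound 3 to compound 4 (0.84 log units; beyond the scatter), is estimated for compound 4. Compound 4 is expected to give about 600 nM in this assay, with a range from 200 nM to 1800 nM.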

Compound 4, inhibition constant: 44.3 nM
For compound 4 the middle estimate is 14-fold (1.13 log units) above the measured one, outside the stated range (below it).
By their numbers in this assay, from the lowest: compounds 4 and 3 (each within the scatter of the next); then compounds 2 and 1 (each within the scatter of the next).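

Exchanging nitro for methyl at this position, on an aromatic carbon para to a large group, gives a 1.9-fold lower number from compound 3 to compound 4 (0.29 log units; within the scatter) in this assay, so the low number of compound 3 does not depend on the nitro group: methyl, with one heavy atom and no hydrogen-bond acceptors, stays within the scatter of it. The other two steps, a 13-fold lower number from compound 2 to compound 4 (1.12 log units; beyond the scatter) and a 20-fold lower number from compound 1 to compound 4 (1.29 log units; beyond the scatter), show that the set divides into two groups, with methyl and nitro on one side and methoxy and fluoro on the other, and that two unlike groups can share the low side. Nothing available here accounts for this grouping.

The compounds shown leave open where an ethyl group, a longer chain, an amine or a carboxylic acid would fall at this position. They also leave open whether chloro would stay with fluoro or join methyl.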